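Methoxy in place of fluoro: from compound 2 to compound 3

The source may hold more compounds than are shown below. What is called first, only, known or untested is meant among the compounds shown, and "the series" means these compounds.

Compound 1 `CC1(C)Cc2c(ccc(C(=O)/C=C/c3ccccc3)c2OCc2ccccc2)O1` gives in a functional assay on NCI-H460 cells (Homo sapiens) for antiproliferative activity, read by MTT assay, with a stated time of 48 h (on this read-out lower numbers stand for stronger inhibition and higher numbers for weaker inhibition), only a limit of the assay, > 100000 nM. Compound 2 `CC1(C)Cc2c(ccc(C(=O)/C=C/c3ccc(F)cc3)c2OCc2ccccc2)O1` gives in this assay 75800 nM, the single number shown in this series. Compound 3 `COc1ccc(/C=C/C(=O)c2ccc3c(c2OCc2ccccc2)CC(C)(C)O3)cc1` differs from compound 2 by methoxy in place of fluoro on an aromatic carbon. Among the measured compounds shown here, the one measured step, an at least 1.3-fold lower number from compound 1 to compound 2 (0.12 log units; that floor lies within the scatter), is small and lies within the scatter, and it concerns a different substituent. Compound 3 is therefore expected to show a 1.3-fold lower number from compound 2 to compound 3 (0.10 log units; within the scatter), no shift beyond the scatter in either direction. Compound 3 is estimated at 60000 nM, within 20000 nM to 150000 nM.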

Compound 3, half-maximal inhibitory concentration: > 100000 nM
Compound 3 ended at the assay's limit; the forecaster's own chance of this, stated with the estimate: 30%; middle value at least 1.6-fold (0.22 log units) away from the limit.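

In this assay compound 3 gives > 100000 nM, which is a limit of the assay. As far as these compounds go, on this aromatic carbon, para to a large group, methoxy in place of fluoro gives an at least 1.3-fold higher number from compound 2 to compound 3 (0.12 log units; that floor lies within the scatter), so the true size of the change stays unknown, and no shift beyond the scatter can be stated. The step between the two compounds at the limit cannot be read, and the series offers only one number: the limit of > 100000 nM in this assay, at which 2 of the 3 values shown sit.

From the compounds shown here alone, whether an amine or a carboxylic acid at this place would give a number well clear of the limit remains open. Also open, going by these compounds, is how far the fluoro of compound 2 truly differs from hydrogen or methoxy.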